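The source may hold more compounds than are shown below. What is called first, only, known or untested is meant among the compounds shown, and "the series" means these compounds.

Working notes on the series. Of the compounds shown here, three sharing a core have been measured in a functional assay on KB cells (Homo sapiens) for cytotoxicity, read by sulforhodamine B assay; a higher number here means a weaker inhibitor, a lower number a stronger inhibitor. Compound 1 `C=C1[C@@H](C/C=C2/C(=O)OC[C@H]2OC(C)=O)[C@]2(C)CC[C@@H](OC(C)=O)[C@@](C)(CO[Si](C)(C)C(C)(C)C)[C@H]2C[C@@H]1O` gives 9790 nM. Compound 2 `C=C1[C@@H](OC(C)=O)C[C@@H]2[C@](C)(COC=O)[C@H](OC(C)=O)CC[C@@]2(C)[C@@H]1C[C@@H](Nc1ccccc1C(=O)O)C1=CCOC1=O` gives 42500 nM. Compound 3 `C=C1[C@@H](OC(C)=O)C[C@@H]2[C@](C)(CO[Si](C)(C)C(C)(C)C)[C@H](OC(C)=O)CC[C@@]2(C)[C@@H]1C[C@@H](Nc1ccc(C(=O)O)cc1)C1=CCOC1=O` gives 5540 nM. Compound 2 thus stands at the highest number of the three, with compound 1 nearest and compound 3 furthest, both gaps beyond the scatter.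

Compound 4 `C=C1[C@@H](OC(C)=O)C[C@@H]2[C@](C)(COC=O)[C@H](OC(C)=O)CC[C@@]2(C)[C@@H]1C[C@@H](Nc1cccc(F)c1)C1=CCOC1=O` is not yet measured. It differs from compound 2 in one place: 3-fluorophenyl in place of 2-carboxyphenyl on an amine nitrogen. Among the compounds with values here, no measured pair shows this change, so the size of the step rests on expectation only. A move to a lower number is expected, of moderate size, a 2.8-fold lower number from compound 2 to compound 4 (0.45 log units; beyond the scatter), though one within the scatter cannot be ruled out. For compound 4 the estimated value in this assay is 15000 nM, expected to fall between 4000 nM and 50000 nM.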

Compound 4, half-maximal inhibitory concentration: 28600 nM
Estimate against measurement, compound 4: 1.9-fold (0.28 log units) below, within the range that was stated.
By their numbers in this assay, from the lowest: compounds 3 and 1 (each within the scatter of the next); then compounds 4 and 2 (each within the scatter of the next).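

In this assay the first step read at this amine nitrogen, 3-fluorophenyl in place of 2-carboxyphenyl, gives a 1.5-fold lower number from compound 2 to compound 4 (0.17 log units; within the scatter). At this position, then, the carboxylic acid can give way to a fluorinated ring with no shift beyond the scatter, and both compounds stay in the same weak range. Nothing available explains this result.

As far as these compounds go, whether a plain phenyl or a saturated alkyl chain on this nitrogen would read alike remains open. So does whether a primary amine or an amide here would move the number.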